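The compounds below may be only part of what the source reports. "The series", "measured", "known", "first", "only" and "open" are said of these compounds alone.

Of the compounds shown here, three sharing one sulfonamide-linked core have been measured in a functional assay on BE(2)-C cells (Homo sapiens) for inhibition, read by MTT assay, with a stated time of 72 h; a higher number here means a weaker inhibitor of growth, a lower number a stronger inhibitor of growth. Compound 1, `O=S(=O)(NCCCCNCc1ccc(Br)cc1)c1cc(C(F)(F)F)cc(C(F)(F)F)c1`, gives 2200 nM. Compound 2, `O=S(=O)(NCCNCc1ccc(-c2ccccc2)cc1)c1cc(C(F)(F)F)cc(C(F)(F)F)c1`, gives 2700 nM. Compound 3, `COc1ccc(CNCCCNS(=O)(=O)c2cc(C(F)(F)F)cc(C(F)(F)F)c2)cc1OC`, gives 3600 nM. On these numbers compound 3 carries the highest value of the three, yet its gaps to compound 2 and to compound 1 both lie within the usual scatter of repeated measurements, so nothing separates the three with confidence.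

The next compound, compound 4, is `O=S(=O)(NCCCNCc1cccc(Cl)c1)c1cc(C(F)(F)F)cc(C(F)(F)F)c1`. It differs from compound 3 in one place: 3-chlorophenyl in place of 3,4-dimethoxyphenyl on a saturated chain carbon bound to an amine nitrogen. Within the data shown here, no pair of measured compounds differs in one place, so there is no measured step to lean on. Compounds 1 and 2 each carry a ring bearing a halogen or a second aromatic ring in the same region and sit close to compound 3, which suggests that this change should move the number little, if at all, beyond the scatter, and if anything toward a lower value.

Compound 4 is therefore expected to give about 2800 nM in this assay, within a range from 1200 nM to 6500 nM. The expected step is a 1.3-fold lower number from compound 3 to compound 4 (0.11 log units; within the scatter), a small shift that would not stand clear of the scatter.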

Compound 4, concentration for 50% growth inhibition: 6900 nM
Compound 4: the middle estimate sits 2.5-fold (0.39 log units) below what was measured; measured number above the stated range.
By their numbers in this assay, from the lowest: compounds 1, 2, 3 and 4 (each within the scatter of the next, the first and the last beyond it).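

In this assay, among these compounds, the first one-place comparison at this position is a 1.9-fold higher number from compound 3 to compound 4 (0.28 log units; within the scatter), so replacing 3,4-dimethoxybenzyl with 3-chlorobenzyl on a saturated chain carbon bound to an amine nitrogen does not stand clear of the scatter and gives no sign of stronger growth inhibition. Among the compounds shown here, the first step beyond the scatter is a 3.1-fold higher number from compound 1 to compound 4 (0.50 log units; beyond the scatter), with (3-chlorobenzyl)amino in place of ((4-bromobenzyl)amino)methyl on a saturated chain carbon, three bonds along the chain from a sulfonamide nitrogen, and it shows that compound 4 is a weaker inhibitor of growth than compound 1, though this single change takes in both the chain and the ring substituent and cannot be assigned to either alone. No measurement is available that bears on what lies behind either step.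

The compounds shown leave open how much of the step from compound 1 to compound 4 belongs to the chain and how much to the ring, a question that 4-bromobenzyl on the chain of compound 4 would address. They also leave open how an unsubstituted benzyl at this position would compare with the 3-chlorobenzyl of compound 4 and the 3,4-dimethoxybenzyl of compound 3.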